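Amide-nitrogen ring swap on compound 1

A few compounds are considered here, and "the series" means these few. Any claim that something is new, unique, unknown or untested is made for them only; others in the source may bear on it.

In a toxicity assay on cells (Cricetulus griseus) for cytotoxicity, read by MTT assay, with a stated time of 72 h (on this read-out lower numbers stand for stronger inhibition and higher numbers for weaker inhibition), compound 1 `Cc1c(C)c2c(c(C)c1OC(=O)CCC(=O)O)CCC(C)(C(=O)NC1CC(C)(C)N([O])C(C)(C)C1)O2` stands at > 300000 nM as a limit of the assay, not a number. Compound 2 `Cc1c(C)c2c(c(C)c1O)CCC(C)(C(=O)NC1CC(C)(C)N([O])C(C)(C)C1)O2` gives 186000 nM and compound 3 `Cc1c(C)c2c(c(C)c1OC(=O)CCC(=O)NC1CC(C)(C)N([O])C(C)(C)C1)CCC(C)(C(=O)NC1CC(C)(C)N([O])C(C)(C)C1)O2` gives 54000 nM as measured numbers.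

Compound 4 `Cc1c(C)c2c(c(C)c1OC(=O)CCC(=O)O)CCC(C)(C(=O)NC1CC(C)(C)N([O])C1(C)C)O2` departs from compound 1 in one place (a group of 10 heavy atoms (8 carbon, 1 nitrogen, 1 oxygen; one five-membered non-aromatic ring with 1 hetero atom) in place of a group of 11 heavy atoms (9 carbon, 1 nitrogen, 1 oxygen; one six-membered non-aromatic ring with 1 hetero atom), on an amide-type nitrogen) and otherwise keeps its structure. The two measured steps act elsewhere and bear on this change only indirectly. Hydrogen in place of (2-carboxyethyl)carbonyl on an oxygen on an aromatic ring gives one step (an at least 1.6-fold lower number from compound 1 to compound 2 (0.20 log units; that floor lies within the scatter)). The second step comes from a group of 12 heavy atoms in place of one oxygen atom, on a carbonyl carbon (an at least 5.5-fold lower number from compound 1 to compound 3 (0.74 log units; beyond the scatter)). Compound 4 keeps the part of compound 1 that both steps alter, so no step beyond the scatter is expected in this assay and a report at the limit is likely. The expected step is a number no higher from compound 1 to compound 4 (the limit leaves the size open) on this estimate. Compound 4 is expected at 300000 nM with an estimated range from 120000 nM to 600000 nM in this assay.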

Compound 4, half-maximal inhibitory concentration: > 300000 nM
Compound 4: only a limit was reported; the forecaster's own chance of this, stated with the estimate: 60%; the middle value sits exactly at the limit.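

No step can be read from compound 1 to compound 4 in this assay, since both results are limits of the assay and not numbers: the limit of > 300000 nM in this assay, at which 2 of the 4 values shown sit. The compounds shown leave open whether the five-membered non-aromatic ring, in place of the six-membered one on the amide-type nitrogen, changes this read-out at all.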